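The source may hold more compounds than are shown below. What is called first, only, known or untested is meant among the compounds shown, and "the series" means these compounds.

Compound 1 `O=C(CSc1nnc(NC(=O)c2c(Cl)cccc2Cl)s1)Nc1ccc(Br)cn1` gives, in a functional assay on NCI-H460 cells (Homo sapiens) for antiproliferative activity, read by MTT assay, with a stated time of 48 h (a higher number here means a weaker inhibitor, a lower number a stronger inhibitor), 16800 nM. Compound 2 `COc1ccccc1C(=O)Nc1nnc(SCC(=O)Nc2ccc(Br)cn2)s1` reaches the limit of this assay, > 80000 nM. That move is an at least 4.7-fold higher number from compound 1 to compound 2 (0.67 log units; beyond the scatter). Compound 3 `COc1ccccc1C(=O)Nc1nnc(SCC(=O)Nc2ccc(C)cn2)s1` likewise stops at the limit of this assay, > 80000 nM. The change a step that the two limits leave unreadable from compound 2 to compound 3 cannot be given a size because of the limit of > 80000 nM in this assay, at which 2 of the 3 values shown sit. Compound 3 therefore stands as one of the two compounds whose result is a limit rather than a number, while compound 1 alone yields a number.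

Compound 4 `COc1ccccc1C(=O)Nc1nnc(SCC(=O)Nc2c(C)ccnc2Cl)s1` differs from compound 3 by 2-chloro-4-methylpyridin-3-yl in place of 5-methylpyridin-2-yl on an amide-type nitrogen. Among the compounds with values here, no measured step alters the group on the amide-type nitrogen in this way; the one step on that side of the molecule, a step that the two limits leave unreadable from compound 2 to compound 3, runs between two limits and carries no readable size. With nothing pointing elsewhere, compound 4 is expected to stay at the limit of this assay, so that a number no higher from compound 3 to compound 4 (the limit leaves the size open) is expected to be a step that cannot be read. The estimate for compound 4 is 80000 nM, with a range from 20000 nM to 200000 nM.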

Compound 4, half-maximal inhibitory concentration: > 80000 nM
Compound 4: a limit, no number; the forecaster's own chance of this, stated with the estimate: 70%; the middle value lies on the limit itself.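

Compound 4 also gives a limit rather than a number, so its steps from compound 2 and from compound 3 cannot be read, because all three compounds stop at the same point: the limit of > 80000 nM in this assay, at which 3 of the 4 values shown sit. The compounds shown leave open whether changing the group on the amide-type nitrogen alters the result in any compound that gives a number.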